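The compounds below may be only part of what the source reports. "The series", "measured", "known", "first", "only" and "open" are said of these compounds alone.

Measured compounds and values in a functional assay on HCT-116 cells (Homo sapiens) for cytotoxicity, read by MTT assay, with a stated time of 48 h; on this read-out higher numbers stand for weaker inhibition and lower numbers for stronger inhibition:
- compound 1 `CN(C)CCNc1ccnc2cc(OCc3ccc(F)cc3)ccc12`: 370 nM
- compound 2 `CC(C)COc1ccc2c(Cl)ccnc2c1`: 2490 nM

Compound 2 stands at the highest of the two numbers, the weaker end of this assay; compound 1, which shares no single-point relation with it, gives the lower number, and the gap between the two values lies beyond the scatter. The step of interest runs from compound 2 to compound 3 `CC(C)Oc1ccc2c(Cl)ccnc2c1`. The change is isopropyl in place of isobutyl on an oxygen on an aromatic ring; the aromatic ether and the chlorine-bearing core stay as they are. Nothing measured here tracks a change of this kind, so the expectation rests on the size of the change alone: one carbon fewer on the same oxygen, with no ring, donor, acceptor or charge altered. The step is expected to be small, in no settled direction, and to stay within the scatter, giving a 1.1-fold higher number from compound 2 to compound 3 (0.05 log units; within the scatter). Compound 3 is therefore estimated at 2800 nM, within a range from 1100 nM to 7500 nM.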

Compound 3, half-maximal inhibitory concentration: 2590 nM
The estimate for compound 3 lay 1.1-fold (0.03 log units) above the measured number; the measured number falls inside the stated range.
By their numbers in this assay, from the lowest: compound 1; then compounds 2 and 3 (each within the scatter of the next).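

In this assay the series gains its first single-point step, on an oxygen on an aromatic ring, and the step reads a 1.0-fold higher number from compound 2 to compound 3 (0.02 log units; within the scatter). Across this pair, the read-out therefore does not resolve the loss of one carbon in going from isobutoxy to isopropoxy, though a single pair cannot show how far this holds for other groups on the oxygen. No measurement shown gives a reason for this result.

Going by these compounds, whether a longer chain, a carboxylic acid or an amine on the same oxygen would move the number beyond the scatter remains open. Compound 1 (370 nM) differs from compounds 2 and 3 in more than one place, so its lower number cannot be assigned to any single change.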